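From an Acetyl-Methoxyphenyl Ether to a Naphthyl Ether

The source may hold more compounds than are shown below. What is called first, only, known or untested is meant among the compounds shown, and "the series" means these compounds.

Of the compounds shown here, three built on one shared core have been measured in a functional assay (aorta) with Oryctolagus cuniculus as the target; a lower number here means tighter binding, a higher number weaker binding. Compound 1 `COc1cc(C(C)=O)ccc1OCCCN1CCC(C(c2ccccc2)c2ccc(F)cc2)CC1` gives 6.31 nM. Compound 2 `COc1cc(C(C)=O)ccc1OCCCCCCN1CCC(C(c2ccc(F)cc2)c2ccc(F)cc2)CC1` gives 6.31 nM. Compound 3 `COc1cc(OCCCN2CCC(C(c3ccc(F)cc3)c3ccc(F)cc3)CC2)ccc1C(C)=O` gives 3.16 nM, the lowest of the three numbers, though both other values lie within the usual scatter of it, so no order among them can be read. Compound 4 `Fc1ccc(C(c2ccc(F)cc2)C2CCN(CCCOc3ccc4ccccc4c3)CC2)cc1` has not yet been measured. It differs from compound 3 in one place: naphthalen-2-yl in place of 4-acetyl-3-methoxyphenyl on an oxygen on a saturated carbon. Among the measured compounds shown here, no measured pair shows this change, so its effect is unknown. For compound 4 the expected step is a 1.6-fold higher number from compound 3 to compound 4 (0.20 log units; within the scatter), a slight weakening that likely stays within the scatter. Compound 4 is estimated at 5 nM, with a range from 1.5 nM to 20 nM.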

Compound 4, dissociation constant: 7.94 nM
Beside the measured number, compound 4's estimate is 1.6-fold (0.20 log units) below it, within the range that was stated.
By their numbers in this assay, from the lowest: compounds 3, 1, 2 and 4 (each within the scatter of the next, the first and the last beyond it).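

In this assay, among the compounds shown here, the swap on this oxygen gives a 2.5-fold higher number from compound 3 to compound 4 (0.40 log units; beyond the scatter), the first change in this set to lie beyond the scatter. The acetyl and methoxy groups can therefore be lost, and a second aromatic ring gained, at only a modest cost, even though naphthalen-2-yl brings no hydrogen-bond acceptors. No available evidence accounts for this step. From the compounds shown here alone, the swap changes the acetyl, the methoxy and the ring count at once, so it remains open which of these matters. A plain phenyl on that oxygen would help to separate them.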